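This account rests on a few compounds, and the source may have more. Where it says the series, first, only, none or still open, it means among the compounds named here.

The measurements come from a functional assay on CHO cells for agonist activity at Alpha-1B adrenergic receptor (Homo sapiens), read by FLIPR and calcium flux; a lower number here means that less compound is needed, a higher number that more compound is needed for the effect.
Compound 1 `Cc1n[nH]cc1-c1cccc2c1CCC2c1ncc[nH]1` gives 902 nM.
Compound 2 `CCCS(=O)(=O)Nc1cccc2c1CCC2c1ncc[nH]1` gives only a limit of the assay, > 10000 nM.
Compound 3 `COc1cccc2c1CCC2c1ncc[nH]1` likewise gives only a limit of the assay, > 10000 nM.

Compound 3 therefore has no exact number; it sits at the limit of > 10000 nM in this assay, at which 2 of the 3 values shown sit, and so stands at the weak end of what has been seen. Compound 4 `Cc1oncc1-c1cccc2c1CCC2c1ncc[nH]1` differs from it in one place: 5-methyl-1,2-oxazol-4-yl in place of methoxy on an aromatic carbon. Among the compounds with values here, two measured steps bear on this change. The step of an at least 11-fold higher number from compound 1 to compound 3 (1.04 log units; beyond the scatter) shows that giving up a five-membered methyl-bearing aromatic ring in favour of methoxy costs a great deal, and the step of an at least 11-fold higher number from compound 1 to compound 2 (1.04 log units; beyond the scatter) shows a similarly large loss when (propylsulfonyl)amino takes that place. Compound 4 puts a five-membered aromatic ring with a methyl group back onto the same carbon, so a large gain is expected, with the step of an at least 6.6-fold lower number from compound 3 to compound 4 (0.82 log units; beyond the scatter) taken as a drop in this assay. The estimate for compound 4 is 1500 nM, with a range from 400 nM to 8000 nM.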

Compound 4, half-maximal effective concentration: > 10000 nM
Compound 4 ended at the assay's limit (the forecaster's own chance of this, stated with the estimate: 25%); middle value at least 6.6-fold (0.82 log units) away from the limit.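

Having a five-membered aromatic ring with a methyl group on this aromatic carbon is therefore not enough: 5-methyl-1,2-oxazol-4-yl in place of 3-methyl-1H-pyrazol-4-yl gives an at least 11-fold higher number from compound 1 to compound 4 (1.04 log units; beyond the scatter), a large change between two rings of the same size. In this assay, within the data shown here, compound 1, at 902 nM, remains the only compound with an exact value. Compound 4 joins the others at a limit of the assay: the limit of > 10000 nM in this assay, at which 3 of the 4 values shown sit.

Steps among compounds 2, 3 and 4 cannot be read, since all three give only that limit, so their order remains unknown. Going by these compounds, it also remains open whether the activity of compound 1 depends on the hydrogen on the pyrazole nitrogen, which 1,3-dimethyl-1H-pyrazol-4-yl, with a methyl on that nitrogen, could test.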